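The source may hold more compounds than are shown below. What is called first, only, known or untested is meant among the compounds shown, and "the series" means these compounds.

Measured so far in the series:

compound 1 `COc1cc(-c2nn(-c3cccc(NC(=O)Nc4ccc(Cl)c(Cl)c4)c3)cc2-c2ccncc2)ccc1Cl` gives 1310 nM in a functional assay on 786-0 cells (Homo sapiens) for inhibition, read by sulforhodamine B assay, with a stated time of 48 h; on this read-out higher numbers stand for weaker inhibition of growth and lower numbers for stronger inhibition of growth
compound 2 `COc1cc(-c2nn(-c3cccc(NC(=O)c4ccc(Cl)c(C(F)(F)F)c4)c3)cc2-c2ccncc2)ccc1Cl` gives 11000 nM in this assay

Going by the values given here, compound 2 holds the higher of the two numbers in this assay; its only measured neighbour is compound 1, and the step of an 8.4-fold higher number from compound 1 to compound 2 (0.92 log units; beyond the scatter) separates them.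

Compound 3 `COc1cc(-c2nn(-c3cccc(NC(=O)Nc4ccc(Cl)c(C(F)(F)F)c4)c3)cc2-c2ccncc2)ccc1Cl` has not been measured. It differs from compound 2 in one place: (4-chloro-3-(trifluoromethyl)phenyl)amino in place of 4-chloro-3-(trifluoromethyl)phenyl on a carbonyl carbon. Among the compounds with values here, the one measured step that bears on this change is an 8.4-fold higher number from compound 1 to compound 2 (0.92 log units; beyond the scatter), which ran the other way at the same carbonyl carbon, an aryl amino group giving way to a bare aryl group while the ring substitution also changed, and the number rose. Compound 3 restores the aryl amino attachment while keeping the ring substitution of compound 2, so a decrease of roughly that size is expected. For compound 3 the expected step is a 7.3-fold lower number from compound 2 to compound 3 (0.87 log units; beyond the scatter). The estimate for compound 3 in this assay is 1500 nM, with a range from 500 nM to 5000 nM.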

Compound 3, concentration for 50% growth inhibition: 1610 nM
Compound 3: the middle estimate sits 1.1-fold (0.03 log units) below what was measured; low and high end bracket the measured number.
By their numbers in this assay, from the lowest: compounds 1 and 3 (each within the scatter of the next); then compound 2.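

With the ring substitution held fixed, the aryl amino attachment on the carbonyl carbon can now be read alone: in this assay the change gives a 6.8-fold lower number from compound 2 to compound 3 (0.83 log units; beyond the scatter) and so accounts for a step of similar size to the earlier one. Trifluoromethyl in place of chloro on an aromatic carbon gives a 1.2-fold higher number from compound 1 to compound 3 (0.09 log units; within the scatter) within the scatter, so among these compounds the aryl amino attachment, and not this ring change, goes with the lower numbers; compound 2 is the only one with the bare aryl group. No measurement at hand explains the effect of the amino attachment.

Still open, on these data alone, is whether a methylamino group or an oxygen atom in place of the amino nitrogen keeps the lower number. Also open, as far as these compounds go, is whether a methoxy or a fluoro group in place of the trifluoromethyl leaves the number unchanged.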